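Pyridinyl urea series: working notes toward compound 4

This account rests on a few compounds, and the source may have more. Where it says the series, first, only, none or still open, it means among the compounds named here.

The compounds are followed in a functional assay on SMMC-7721 cells (Homo sapiens) for inhibition, read by MTT assay, with a stated time of 48 h; a lower number here means a stronger inhibitor, a higher number a weaker inhibitor. Compound 1 `COc1cc(NC(=O)Nc2ccccn2)cc(-c2cccnc2)c1OC` gives 22400 nM. Compound 2 `O=C(Nc1ccccn1)Nc1cc(-c2cncnc2)ccc1OC(F)(F)F` gives 21600 nM, the lowest of the two numbers available, but its nearest neighbour, compound 1, sits within the scatter of it, so the two are read as equivalent rather than ordered. Compound 3 `COc1ccc(-c2cc(NC(=O)Nc3ccncc3)cc(OC)c2OC)cn1` gives "not determined" (no result reported) in this assay, so no result is reported for it.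

Compound 4 `O=C(Nc1ccncc1)Nc1cc(-c2cncnc2)ccc1OC(F)(F)F` is the next entry to be measured. It differs from compound 2 in one place: pyridin-4-yl in place of pyridin-2-yl on an amide-type nitrogen. Among the measured compounds shown here, no pair of measured compounds shows this change, so no step size can be taken from the data; the only guide is that compound 1 and compound 2, which differ substantially in their substitution on the shared core, still fall within the scatter of each other in this assay. On that basis no shift beyond the scatter is expected in either direction from compound 2 to compound 4. Compound 4 is estimated at 22000 nM, with a range of 8000 nM to 60000 nM. This amounts to an expected step of a 1.0-fold higher number from compound 2 to compound 4 (0.01 log units; within the scatter).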

Compound 4, half-maximal inhibitory concentration: 3990 nM
For compound 4 the middle estimate is 5.5-fold (0.74 log units) above the measured one; the measured number lies below the stated range.
By their numbers in this assay, from the lowest: compound 4; then compounds 2 and 1 (each within the scatter of the next).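

In this assay, among the compounds shown here, the exchange of pyridin-2-yl for pyridin-4-yl on an amide-type nitrogen gives a 5.4-fold lower number from compound 2 to compound 4 (0.73 log units; beyond the scatter) and is the first step that can be read at all. The two groups match in heavy atoms, hydrogen-bond donors and acceptors and differ only in how the same atoms are joined, so this position responds to a change that leaves all those counts untouched. Nothing measured bears on why the number moves.

Compound 3 also carries pyridin-4-yl on this nitrogen but has no result, so whether the step holds on another substitution of the shared core cannot be read. Also open, going by these compounds, is what phenyl, or a pyridinyl group bearing an amine, would give on this same amide-type nitrogen.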